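Swapping the halogenated ring on a nicotinamide amide

A few compounds are considered here, and "the series" means these few. Any claim that something is new, unique, unknown or untested is made for them only; others in the source may bear on it.

Measured compounds:
- compound 1, `O=C(Nc1ccc(I)cc1)c1cncc(N2CC3CC(C2)N3)c1`: 0.366 nM
- compound 2, `O=C(c1cncc(N2CC3CC(C2)N3)c1)N1CCCc2ccccc21`: 0.196 nM
- compound 3, `O=C(c1cncc(N2CC3CC(C2)N3)c1)N1CCc2ccccc2C1`: 0.031 nM

All three compounds were tested in an assay on membranes from Cerebral cortex for displacement of a labelled ligand from Neuronal acetylcholine receptor; alpha4/beta2 (Rattus norvegicus); on this read-out higher numbers stand for weaker inhibition and lower numbers for stronger inhibition. Compound 1 gives 0.366 nM, the highest of the three numbers. Compound 2 sits close to it, with a difference that falls within the usual scatter, so no order between these two can be claimed. Compound 3 lies clearly lower, beyond the scatter, and is the only one that stands apart in this small set.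

Compound 4, `O=C(Nc1ccccc1F)c1cncc(N2CC3CC(C2)N3)c1`, has not yet been measured. It differs from compound 1 in one place: 2-fluorophenyl in place of 4-iodophenyl on an amide-type nitrogen. Among the compounds with values here, no measured pair here shows what such a swap of one halogenated ring for another does, so the expectation rests on the general picture that all three measured compounds bind tightly. For compound 4 a somewhat weaker result is expected, a step from compound 1 that may edge just beyond the scatter: a 2.7-fold higher number from compound 1 to compound 4 (0.44 log units; beyond the scatter). The estimate for compound 4 in this assay is 1 nM, with a likely range from 0.2 nM to 5 nM.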

Compound 4, inhibition constant: 0.315 nM
The estimate for compound 4 lay 3.2-fold (0.50 log units) above the measured number, within the range that was stated.
By their numbers in this assay, from the lowest: compound 3; then compounds 2, 4 and 1 (each within the scatter of the next).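

In this assay, 2-fluorophenyl in place of 4-iodophenyl on the amide-type nitrogen gives a 1.2-fold lower number from compound 1 to compound 4 (0.07 log units; within the scatter), so this pair cannot be put in order. Within the data shown here, this is the first measured pair that differs at this place, and it shows that a ring carrying fluorine can stand in for a ring carrying iodine with no change that can be told apart from the scatter. No measured property of either group is available to explain this result.

The kind of halogen and its place on the ring differ together in this step, so the compounds shown leave their separate contributions open. They also leave open what a plain phenyl, or a phenyl bearing a methoxy group or a carboxylic acid, would give on the same nitrogen.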